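This account rests on a few compounds, and the source may have more. Where it says the series, first, only, none or still open, it means among the compounds named here.

Among the measured compounds shown here, in a functional assay on SF-295 cells (Homo sapiens) for inhibition (a lower number here means a stronger inhibitor of growth, a higher number a weaker inhibitor of growth), compound 1 `NC(=O)c1cc(Cl)ccc1NC(=O)COc1ccccc1` gives 1960 nM as its number, while compound 2 `NC(=O)c1cc(I)ccc1NC(=O)COc1ccccc1` gives 223 nM as the lowest of the two numbers so far. Compound 3 `COc1ccc(NC(=O)COc2ccccc2)c(C(N)=O)c1` follows from compound 2 by methoxy in place of iodo on an aromatic carbon with methoxy in place of iodo on an aromatic carbon, meta to a carbamoyl group and para to a large group. For the measured compounds named here, only one measured step bears on this change, and an 8.8-fold lower number from compound 1 to compound 2 (0.94 log units; beyond the scatter) came with iodo in place of chloro. Going by the values given here, no methoxy compound has been measured, so the only guide without iodo is compound 1 at 1960 nM in this series. A higher number than that of compound 2 is therefore expected, with a step similar to or somewhat smaller than the measured one. An estimated 6.3-fold higher number from compound 2 to compound 3 (0.80 log units; beyond the scatter) is expected on this reasoning. Compound 3 is estimated at 1400 nM with 350 nM to 5000 nM as the expected range.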

Compound 3, concentration for 50% growth inhibition: 650 nM
Compound 3: the middle estimate sits 2.2-fold (0.33 log units) above what was measured; the range from low to high includes it.
By their numbers in this assay, from the lowest: compound 2; then compound 3; then compound 1.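

In this assay, the position para to a large group is not limited to halogens: methoxy in place of iodo comes with a 2.9-fold higher number from compound 2 to compound 3 (0.46 log units; beyond the scatter), while methoxy in place of chloro comes with a 3.0-fold lower number from compound 1 to compound 3 (0.48 log units; beyond the scatter). Methoxy, which adds a hydrogen-bond acceptor by the count, therefore falls between the two halogens, with both steps beyond the scatter, and iodo remains the group with the lowest number of the three. Nothing available accounts for this order of iodo, methoxy and chloro.

Open, from the compounds shown here alone, is where a bromo, a methyl, an amine or a carboxylic acid would fall at this position relative to these three groups. Also open, going by these compounds, is whether the same order would hold with a change elsewhere on the shared core.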